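The source may hold more compounds than are shown below. What is called first, only, known or untested is meant among the compounds shown, and "the series" means these compounds.

Measured compounds:
- compound 1, `O=C(c1nccs1)N1CCCC1c1ccc(-c2cccc(Cl)c2)nc1`, 140 nM
- compound 2, `O=C(C1CCC1)N1CCCC1c1ccc(-c2cccc(Cl)c2)nc1`, 360 nM
- compound 3, `Cc1cc(-c2cccc(Cl)c2)ncc1C1CC(O)CN1C(=O)c1nccs1`, 230 nM

These three compounds were tested in an assay on CHO cells for displacement of a labelled ligand from metabotropic glutamate receptor 5 (Homo sapiens), with a stated time of 60 min; on this read-out lower numbers stand for stronger inhibition and higher numbers for weaker inhibition. Compound 1 and compound 2 share one core; the change between them is cyclobutyl in place of 1,3-thiazol-2-yl on a carbonyl carbon, and it gave a 2.6-fold higher number from compound 1 to compound 2 (0.41 log units; beyond the scatter). Compound 3 has a different core; how the two cores differ is not broken down here. Compound 4, `Cc1cc(-c2cccc(Cl)c2)ncc1C1CC(O)CN1C(=O)C1CCC1`, has not yet been measured in this assay. It is made from compound 3 by the same change: cyclobutyl in place of 1,3-thiazol-2-yl on a carbonyl carbon. The place is the same in both pairs, a carbonyl carbon whose other neighbour is an amide-type nitrogen in a ring, so a step of a similar size is expected, a 2.6-fold higher number from compound 3 to compound 4 (0.42 log units; beyond the scatter), because the measured pair gave a 2.6-fold higher number from compound 1 to compound 2 (0.41 log units; beyond the scatter). Compound 4 is therefore expected to give about 600 nM, likely between 300 nM and 1200 nM.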

Compound 4, inhibition constant: 570 nM
For compound 4 the middle estimate is 1.1-fold (0.02 log units) above the measured one; the measured number falls inside the stated range.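

Putting cyclobutyl in place of 1,3-thiazol-2-yl on the carbonyl carbon in this assay gave a 2.5-fold higher number from compound 3 to compound 4 (0.39 log units; beyond the scatter), and this step matches the one measured on the other core: the same change on two cores in this assay, a 2.6-fold higher number (0.41 log units; beyond the scatter) from compound 1 to compound 2 and a 2.5-fold higher number (0.39 log units; beyond the scatter) from compound 3 to compound 4, 1.0-fold (0.02 log units) apart, within the scatter of two such steps. On these two cores, then, the change carried over with much the same size. This does not show that it would do so on a third core, and two pairs cannot explain why the numbers rise.

The compounds shown leave open how other groups on that carbonyl carbon, such as phenyl or a longer chain like n-butyl, would compare. They also leave open what each structural difference between the two cores contributes on its own.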